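Working notes on the sulfur-linked change from compound 3 to compound 4

This account rests on a few compounds, and the source may have more. Where it says the series, first, only, none or still open, it means among the compounds named here.

Compound 3 `COc1ccc(Sc2nc3cc(N)cc(N)c3nc2-c2ccccc2)cc1` is known in a functional assay on SNB-19 cells (Homo sapiens) for inhibition, read by sulforhodamine B assay, with a stated time of 48 h (on this read-out higher numbers stand for lower toxicity in this test and lower numbers for higher toxicity in this test), only as < 100000 nM, which is a limit of the assay and not a number. Compound 1 `Nc1cc(N)c2nc(-c3ccccc3)c(Oc3ccc(Cl)c(Cl)c3)nc2c1` likewise stands in this assay at < 100000 nM, again a limit. Compound 2 `Nc1cc(N)c2nc(-c3ccccc3)c(NCc3ccc(F)cc3)nc2c1` gives 52500 nM in this assay. Two of the three values shown thus sit at the limit of < 100000 nM in this assay, at which 2 of the 3 values shown sit, so the measured steps cannot be sized: a step that the two limits leave unreadable from compound 1 to compound 3, a step that the limit leaves unreadable from compound 2 to compound 3 and a step that the limit leaves unreadable from compound 1 to compound 2 are all unreadable on this read-out.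

Compound 4 `Nc1cc(N)c2nc(-c3ccccc3)c(Sc3ccc(Cl)c(Cl)c3)nc2c1` carries 3,4-dichlorophenyl in place of 4-methoxyphenyl on a sulfur. Within the data shown here, no measured step follows this change on a sulfur; the only compound bearing a 3,4-dichlorophenyl group elsewhere is compound 1, whose value is a limit, and compound 3 itself is a limit. No direction can therefore be read for the change, and the step from compound 3 to compound 4 is expected to be a step that the limit leaves unreadable from compound 3 to compound 4, which is to be taken as no step beyond the scatter rather than a measured difference. Compound 4 is accordingly estimated to give 60000 nM in this assay, within a range of 15000 nM to 100000 nM, with a high chance that only a limit is again reported.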

Compound 4, concentration lethal to 50% of the cells: < 100000 nM
Compound 4: only a limit was reported; the forecaster's own chance of this, stated with the estimate: 60%; the middle value does not contradict the limit.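

In this assay compound 4 gives < 100000 nM as a limit and not a number. The steps to compound 4 from compound 1, compound 2 and compound 3 cannot be read, because the values rest on a limit: the limit of < 100000 nM in this assay, at which 3 of the 4 values shown sit.

The compounds shown leave open whether in this assay 3,4-dichlorophenyl in place of 4-methoxyphenyl on a sulfur has any size or direction.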